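A Cyclopropylphenyl Swap on a Thiazolidinone Amide

A few compounds are considered here, and "the series" means these few. Any claim that something is new, unique, unknown or untested is made for them only; others in the source may bear on it.

Compound 1, `COc1ccc(OC)c(N2C(=O)CSC2c2cccc(C(=O)NCCCCc3ccccc3)c2)c1`, gives in a functional assay on HOS-TE85 cells (Homo sapiens) for inhibition, read by CCK-8 assay, with a stated time of 72 h (a lower number here means a stronger inhibitor, a higher number a weaker inhibitor), only a limit of the assay, > 1000 nM. Compound 2, `COc1ccccc1N1C(=O)CSC1c1cccc(C(=O)NCCCCN2C(=O)C=CC2=O)c1`, likewise stops at a limit in this assay, > 1000 nM. Compound 3, `O=C(NCCCCc1ccccc1)c1cccc(C2OCC(=O)N2c2cccc(F)c2)c1`, built on a different core, reaches 320 nM in this assay. Compound 1 therefore stands at the limit of > 1000 nM in this assay, at which 2 of the 3 values shown sit, with no number of its own to compare against. Compound 4, `O=C(NCCCCc1ccccc1)c1cccc(C2SCC(=O)N2c2ccc(C3CC3)cc2)c1`, alters compound 1 in one place: 4-cyclopropylphenyl in place of 2,5-dimethoxyphenyl on an amide-type nitrogen in a ring. Within the data shown here, no measured step between related compounds is available to guide this change, yet a moderate gain in this assay is expected, estimated as an at least 1.6-fold lower number from compound 1 to compound 4 (0.22 log units; that floor lies within the scatter). Compound 4 is accordingly expected near 600 nM, within a range from 200 nM to 3000 nM.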

Compound 4, half-maximal inhibitory concentration: 217 nM
Estimate against measurement, compound 4: 2.8-fold (0.44 log units) above; measured number inside the range.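

Placing 4-cyclopropylphenyl instead of 2,5-dimethoxyphenyl on the amide-type nitrogen in the ring gives, in this assay, an at least 4.6-fold lower number from compound 1 to compound 4 (0.66 log units; beyond the scatter). Among these compounds, this is the first readable step, and it shows that the group at this position can change the result, even when it carries no hydrogen-bond acceptors. Compound 1 gives only a limit, so the step has a minimum size but no exact one: the limit of > 1000 nM in this assay, at which 2 of the 4 values shown sit.

As far as these compounds go, whether the gain comes from losing the methoxy groups or from adding the cyclopropyl ring remains open. A plain phenyl or a 4-tert-butylphenyl at this position could help separate the two.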